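Fluoroethoxy Swap on a Second Core: Expected Half-Life

The source may report more compounds than this note shows. Statements on the series, on what has been measured and on what is new or still open speak of the compounds shown alone.

Compound 1 `CO/N=C1/C(=O)N(Cc2nc3ccccc3n2CCCCO)c2cnccc21` gives 1.4 h in an ADME assay on liver (Homo sapiens) for metabolic stability; a lower number here means that the compound disappears faster, a higher number that the compound lasts longer.
Compound 2 `CO/N=C1/C(=O)N(Cc2nc3ccccc3n2CCCCO)c2ncccc21` gives 0.517 h in this assay.
Compound 3 `O=C1/C(=N/OCCF)c2ccncc2N1Cc1nc2ccccc2n1CCCCO` gives 1.67 h in this assay.

Compound 3 differs from compound 1 by one change, (fluoromethyl in place of hydrogen on a saturated chain carbon bound to an oxygen), and that change gave a 1.2-fold higher number from compound 1 to compound 3 (0.08 log units; within the scatter). Compound 2 is built from the same atoms as compound 1, joined differently; the difference between the two cores is not broken down here, but in this assay compound 2 has the lowest of the three values, and its gaps to compound 1 and compound 3 lie beyond the scatter.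

Compound 4 `O=C1/C(=N/OCCF)c2cccnc2N1Cc1nc2ccccc2n1CCCCO` is not yet measured. It differs from compound 2 by fluoromethyl in place of hydrogen on a saturated chain carbon bound to an oxygen, the same change as from compound 1 to compound 3. Because a 1.2-fold higher number from compound 1 to compound 3 (0.08 log units; within the scatter) stayed within the scatter, the expected step is a 1.2-fold higher number from compound 2 to compound 4 (0.06 log units; within the scatter), resting on compound 2 and its value 0.517 h. For compound 4 the estimate is 0.6 h, with a range from 0.3 h to 1.2 h.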

Compound 4, half-life: 0.733 h
The estimate for compound 4 lay 1.2-fold (0.09 log units) below the measured number, within the range that was stated.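

In this assay, replacing methoxy with 2-fluoroethoxy gave a 1.4-fold higher number from compound 2 to compound 4 (0.15 log units; within the scatter), and this step can be set beside the earlier one: the same change on two cores in this assay, a 1.2-fold higher number (0.08 log units; within the scatter) from compound 1 to compound 3 and a 1.4-fold higher number (0.15 log units; within the scatter) from compound 2 to compound 4, 1.2-fold (0.08 log units) apart, within the scatter of two such steps. The change therefore carries from one core to the other in a limited sense: on neither core does it shift the half-life by more than repeat measurements would. This does not show that the change lengthens the half-life, and two cores say nothing about a third.

On these data alone, whether a longer chain on that oxygen, or an amine at the end of the chain, would leave the half-life equally unmoved stays open. As far as these compounds go, how the 2-fluoroethoxy group behaves on other cores also stays open.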